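Replacing Cyclopropyl with Pentan-3-yl on the Amine Nitrogen

The source may report more compounds than this note shows. Statements on the series, on what has been measured and on what is new or still open speak of the compounds shown alone.

Measured in a functional assay (Nicotiana tabacum); a lower number here means a stronger inhibitor, a higher number a weaker inhibitor:
- compound 1 `CCCCNc1nc(SC)nc2ncccc12`: 270 nM
- compound 2 `CCCCCCCNc1nc(SC)nc2ncccc12`: 4070 nM
- compound 3 `CSc1nc(NC2CC2)c2cccnc2n1`: 4900 nM

Compound 3 lies within the scatter of compound 2, and both stand well above compound 1 in this assay. Compound 4 `CCC(CC)Nc1nc(SC)nc2ncccc12` has not yet been measured. It carries pentan-3-yl in place of cyclopropyl on a nitrogen on an aromatic ring.

Among the measured compounds shown here, two measured steps bear on this change. With cyclopropyl in place of butyl, the data show an 18-fold higher number from compound 1 to compound 3 (1.26 log units; beyond the scatter). An open chain on that nitrogen can thus go with a much lower number than cyclopropyl, but it need not, since propyl in place of hydrogen on a saturated chain carbon gives a 15-fold higher number from compound 1 to compound 2 (1.18 log units; beyond the scatter). Neither step involves pentan-3-yl, so a moderate move towards a lower number is expected, short of the full distance to compound 1. The expected change is a 3.3-fold lower number from compound 3 to compound 4 (0.51 log units; beyond the scatter). The estimated value for compound 4 is 1500 nM, with a range of 400 nM to 5000 nM.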

Compound 4, half-maximal inhibitory concentration: 2720 nM
Compound 4: the middle estimate sits 1.8-fold (0.26 log units) below what was measured; measured number inside the range.
By their numbers in this assay, from the lowest: compound 1; then compounds 4, 2 and 3 (each within the scatter of the next).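

In this assay, pentan-3-yl, which has no ring, in place of cyclopropyl on a nitrogen on an aromatic ring gives a 1.8-fold lower number from compound 3 to compound 4 (0.26 log units; within the scatter), so at this position the two groups cannot be told apart. With pentan-3-yl in place of butyl on the same nitrogen, the data show a 10-fold higher number from compound 1 to compound 4 (1.00 log units; beyond the scatter), so having an open group there is not enough to match compound 1, and butyl is the only group shown that stands clear of the others. No evidence is available that accounts for this result.

The compounds shown leave open whether a straight pentyl or propyl chain on that nitrogen would stay close to butyl. They also leave open how a cyclopentyl ring, or a butyl chain ending in a hydroxyl or an amine, would compare.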